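The source may report more compounds than this note shows. Statements on the series, on what has been measured and on what is new or still open speak of the compounds shown alone.

The study works through a small set of compounds built on one shared core. Compound 1 `CCCCCCCCc1ccc(CC[C@@H]2CCCN2)cc1` has no result in a functional assay on FL5.12 cells (Mus musculus), read by flow cytometry, with a stated time of 3 h, tested at 40 uM; on this read-out lower numbers stand for a weaker effect and higher numbers for a stronger effect at the one concentration tested: for compound 1 the read-out is given as "not determined" (no result reported). Compound 2 `CCCCCCCCc1ccc(C(=O)C[C@@H]2C[C@@H](O)CN2)cc1` is in the same position: in this assay compound 2 is given as "not determined" (no result reported). For the measured compounds named here, compound 3 `CCCCCCCCc1ccc(CC(=O)[C@@H]2C[C@@H](OP(=O)(O)O)CN2)cc1` is the only member with a number: in this assay compound 3 gives 0%. On the numbers shown, compound 3 therefore stands as the sole measured point, and that point lies at the bottom of the scale, with no effect recorded at the one concentration tested.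

Compound 4 `CCCCCCCCc1ccc(CC(=O)[C@H]2C[C@H](OP(=O)(O)O)CN2)cc1` is the next compound to be measured. It differs from compound 3 as follows: the two compounds have the same atoms and bonds and differ only in configuration as drawn: 2 of 2 stereo elements differ (all stereocentres are inverted: mirror images); a stereocentre at a saturated ring carbon is drawn S in compound 3 and R in compound 4; a stereocentre at a saturated ring carbon is drawn R in compound 3 and S in compound 4. Going by the values given here, no step between two measured compounds is available, so there is nothing from which the size of a change from one mirror image to the other can be read off. Among the compounds with values here, since the only measured compound, compound 3, gives 0%, the step in this assay can only go upward or stay within the scatter, and there is no precedent to say which. A modest upward step is expected, a number 10 percentage points higher from compound 3 to compound 4 (within the scatter), with wide uncertainty around it. Compound 4 is accordingly expected to give about 10% in this assay, within a range from 0% to 45%.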

Compound 4, a percentage reported as activity, at one concentration (the size of the read-out at that concentration, not a potency): 8%
Compound 4: the middle estimate sits 2 percentage points above what was measured, and the stated range covers the measured number.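

With this mirror-image pair, this assay yields its first step in the set, which compounds 1 and 2 could not supply without a number: inverting both stereocentres at the saturated ring carbons gives a number 8 percentage points higher from compound 3 to compound 4 (within the scatter). At these two stereocentres taken together, the configuration as drawn therefore does not separate the two compounds on this read-out at the one concentration tested, and both stay near the bottom of the scale. The comparison has no other change to weigh against it: the fact that compounds 3 and 4 differ only in the configuration as drawn.

The compounds shown leave open whether a form with only one of the two stereocentres inverted would read differently from this pair, since here the two centres change only together. Also open, on these data alone, is what a carboxylic acid in place of the phosphate group, or a longer chain on the shared core, would do in this assay, given that a single pair near the bottom of the scale says nothing about what would raise the read-out.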